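Methyl for fluoro on a pyridine ring: compound 4

This account rests on a few compounds, and the source may have more. Where it says the series, first, only, none or still open, it means among the compounds named here.

Three compounds share the same basic side chain attached through an oxygen to an aromatic ring. Compound 1 `Cc1cncc(OC[C@@H]2CCCN2C)c1` was tested in an assay on membranes from brain for displacement of a labelled ligand from Neuronal acetylcholine receptor; alpha4/beta2 (Rattus norvegicus) (a higher number here means a weaker inhibitor, a lower number a stronger inhibitor), and gives 0.48 nM. Compound 2 `CN1CCC[C@H]1COc1cncc(F)c1` gives 0.69 nM, and compound 3 `CN1CCC[C@H]1COc1ccc(F)nc1` gives 2.56 nM. Compound 2 and compound 3 hold the same atoms joined differently; the difference between the two cores is not broken down here. Compound 4 `Cc1ccc(OC[C@@H]2CCCN2C)cn1` has not yet been measured. Its change from compound 3 is methyl in place of fluoro on an aromatic carbon. The same kind of change, (methyl in place of fluoro on an aromatic carbon), made a step of a 1.4-fold lower number from compound 2 to compound 1 (0.16 log units; within the scatter). The two places differ: in compound 1 the methyl sits two atoms from the ring nitrogen and meta to a group of 8 heavy atoms, in compound 4 next to the ring nitrogen and para to that group. Because of a 1.4-fold lower number from compound 2 to compound 1 (0.16 log units; within the scatter), a similar small step is expected, a 1.4-fold lower number from compound 3 to compound 4 (0.15 log units; within the scatter), giving compound 4 an estimated 1.8 nM, between 0.7 nM and 4.5 nM.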

Compound 4, inhibition constant: 1.26 nM
Estimate against measurement, compound 4: 1.4-fold (0.15 log units) above, and the stated range covers the measured number.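

Swapping fluoro for methyl gives a 2.0-fold lower number from compound 3 to compound 4 (0.31 log units; beyond the scatter) in this assay, a modest step on this core. Set beside the earlier case, the two steps do not differ beyond what repeated measurements would scatter: the same change on two cores in this assay, a 1.4-fold lower number (0.16 log units; within the scatter) from compound 2 to compound 1 and a 2.0-fold lower number (0.31 log units; beyond the scatter) from compound 3 to compound 4, 1.4-fold (0.15 log units) apart, within the scatter of two such steps. Among these compounds, this shows agreement in size across these two cores, but it rests on only two pairs, and the methyl sits at a different place on each ring, so it gives no rule for other cores or places.

The compounds shown leave open how chloro, methoxy or a longer chain such as ethyl would compare on the aromatic carbon next to the ring nitrogen. They also leave open whether the swap behaves alike with a hydrogen replacing the methyl on the side-chain nitrogen.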